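The source may hold more compounds than are shown below. What is called first, only, known or untested is meant among the compounds shown, and "the series" means these compounds.

Measured in a functional assay (aorta) with Rattus norvegicus as the target; a higher number here means that more compound is needed for the effect, a lower number that less compound is needed:
- compound 1 `CNC(=N)Nc1nc(-c2ccc(OC)cc2)c(-c2ccc(OC)cc2)s1`: 1.2 uM
- compound 2 `COc1ccc(-c2nc(/N=C(\N)N(C)C)sc2-c2ccc(OC)cc2)cc1`: 4.8 uM
- compound 3 `COc1ccc(-c2nc(/N=C(\N)NC3CCCCC3)sc2-c2ccc(OC)cc2)cc1`: > 100 uM

Compound 3 stands only at a limit of this assay, not at a number: the limit of > 100 uM in this assay, at which 1 of the 3 values shown sits.

Compound 4 `C/N=C(/NC)Nc1nc(-c2ccc(OC)cc2)c(-c2ccc(OC)cc2)s1` differs from compound 3 as follows: a group of 6 heavy atoms (3 carbon, 3 nitrogen; no ring) in place of a group of 10 heavy atoms (7 carbon, 3 nitrogen; one six-membered non-aromatic ring of carbon only), on an aromatic carbon. In words, a group of 6 heavy atoms replaces the group of 10 heavy atoms with its six-membered ring, on an aromatic carbon.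

The closest measured change is the large at least 20-fold higher number from compound 2 to compound 3 (1.31 log units; beyond the scatter). The large at least 83-fold higher number from compound 1 to compound 3 (1.92 log units; beyond the scatter) points the same way, while the ringless groups differ only modestly, with a 4.0-fold higher number from compound 1 to compound 2 (0.60 log units; beyond the scatter). Losing the ring should therefore undo most of the large step.

The estimated step, to a lower number, is an at least 33-fold lower number from compound 3 to compound 4 (1.52 log units; beyond the scatter).

For compound 4 the expected value is 3 uM, with an estimated range of 0.8 uM to 15 uM.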

Compound 4, concentration for half-maximal effect: 2.4 uM
The estimate for compound 4 lay 1.3-fold (0.10 log units) above the measured number; the range from low to high includes it.
By their numbers in this assay, from the lowest: compounds 1, 4 and 2 (each within the scatter of the next, the first and the last beyond it). At a limit, above all of these: compound 3.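

Without the six-membered ring, the number in this assay returns to the range of the ringless groups: an at least 41-fold lower number from compound 3 to compound 4 (1.61 log units; beyond the scatter). From the compounds shown here alone, compound 3 stands only at a limit, so the full size of that step stays unknown: the limit of > 100 uM in this assay, at which 1 of the 4 values shown sits. The ringless groups do not separate, with a 2.0-fold lower number from compound 2 to compound 4 (0.30 log units; within the scatter) and a 2.0-fold higher number from compound 1 to compound 4 (0.30 log units; within the scatter), so their differing arrangements of methyl groups change little here.

Open, going by these compounds, is how large the group can grow before the number rises, for instance with ethyl or isopropyl. On these data alone, whether the ring itself or only the group's size matters also remains open; an open hexyl chain or a cyclopropyl group would separate the two.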